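The source may hold more compounds than are shown below. What is called first, only, known or untested is meant among the compounds shown, and "the series" means these compounds.

Compound 1 `CCCCCCCCn1nc(-c2cccnc2)c2ccccc2c1=O` in an assay on isolated protein (Oryctolagus cuniculus) with Thromboxane-A synthase (Homo sapiens) as the target, tested at 1 uM (a higher number here means more inhibition at the concentration tested (going by the name of the read-out), a lower number less inhibition), gives 99%, whereas compound 2 `CCOC(=O)Cn1nc(-c2cccnc2)c2ccccc2c1=O` gives 28% in this assay. Among the measured compounds shown here, compound 2 therefore stands lowest of the two measured numbers, and the only measured step, a number 71 percentage points lower from compound 1 to compound 2 (beyond the scatter), is large and beyond the scatter. Compound 3 `CCOC(=O)CCCn1nc(-c2cccnc2)c2ccccc2c1=O` differs from compound 2 as follows: 2-(ethoxycarbonyl)ethyl in place of ethoxycarbonyl on a saturated chain carbon bound to an aromatic nitrogen. The step from compound 1 to compound 2 is the one that bears on this change, since it shows that a long saturated chain on the aromatic nitrogen is linked to high inhibition and a short ethoxycarbonyl-bearing chain to low inhibition; the change to compound 3 moves part of the way back toward the longer chain. An upward step of moderate size, a number 32 percentage points higher from compound 2 to compound 3 (beyond the scatter), is expected. Compound 3 is estimated at 60%, with a range from 30% to 90%.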

Compound 3, a percentage reported as inhibition, at one concentration (the size of the read-out at that concentration, not a potency): 95%
Compound 3: middle estimate off by 35 percentage points, on the low side; the measured number lies above the stated range.
By their numbers in this assay, from the lowest: compound 2; then compounds 3 and 1 (each within the scatter of the next).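

In this assay, the ester group is present in both compound 2 and compound 3, yet the change from ethoxycarbonyl to 2-(ethoxycarbonyl)ethyl on a saturated chain carbon bound to an aromatic nitrogen gives a number 67 percentage points higher from compound 2 to compound 3 (beyond the scatter), so the ester alone does not go with low inhibition. With the longer chain, the ester also stands level with the all-carbon chain, as ethoxycarbonyl in place of pentyl gives a number 4 percentage points lower from compound 1 to compound 3 (within the scatter). No measurement offered here accounts for these steps.

The compounds shown leave open whether a carboxylic acid or an amine at the end of the 3-(ethoxycarbonyl)propyl chain, in place of the ester, would keep inhibition at this level. They also leave open how a longer chain carrying the ester would read, and the single tested concentration does not separate compound 1 from compound 3.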